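This account rests on a few compounds, and the source may have more. Where it says the series, first, only, none or still open, it means among the compounds named here.

In a functional assay on KB cells (Homo sapiens) for inhibition (on this read-out higher numbers stand for weaker inhibition and lower numbers for stronger inhibition), compound 1 (`Nc1nc2cc(Cl)c(Cl)cc2n1Cc1ccc(Cl)c(Cl)c1`) gives 35000 nM. Compound 2 (`Clc1ccc(Cn2c(Cl)nc3cc(Cl)c(Cl)cc32)cc1Cl`) reads > 100000 nM, which is a limit of the assay. Compound 3 (`Clc1ccc(Cn2c(Br)nc3cc(Cl)c(Cl)cc32)cc1`) reads > 100000 nM, also only a limit, so its true position is not known. Among the compounds with values here, the series so far stands largely at the limit of > 100000 nM in this assay, at which 2 of the 3 values shown sit.

Compound 4 (`Clc1ccc(Cn2c(Br)nc3cc(Cl)c(Cl)cc32)cc1Cl`) differs from compound 3 by chloro in place of hydrogen on an aromatic carbon. Within the data shown here, the one measured step, an at least 2.8-fold higher number from compound 1 to compound 2 (0.45 log units; beyond the scatter), is chloro in place of amino, a different exchange, so it gives no direct size for this change. The expected step in this assay is a number no higher from compound 3 to compound 4 (the limit leaves the size open), with none expected beyond the scatter. For compound 4 the estimate is 100000 nM, with an expected range of 40000 nM to 200000 nM.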

Compound 4, half-maximal inhibitory concentration: > 100000 nM
Compound 4: a limit, no number (the forecaster's own chance of this, stated with the estimate: 70%); the middle value lies on the limit itself.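

In this assay the added chloro, ortho to a chloro group, does not bring the bromo series off the limit: compound 4 reads > 100000 nM, which is a limit and not a number. Bromo in place of amino gives an at least 2.8-fold higher number from compound 1 to compound 4 (0.45 log units; beyond the scatter), in the same direction as chloro in place of amino, with an at least 2.8-fold higher number from compound 1 to compound 2 (0.45 log units; beyond the scatter). The steps among the compounds at the limit cannot be read, and the series now sits mostly in one place: the limit of > 100000 nM in this assay, at which 3 of the 4 values shown sit.

On these data alone, whether the added chloro or the exchange of bromo for chloro changes inhibition at all stays open. Also open, as far as these compounds go, is how a hydroxyl or a methylamino group would read in place of amino, with compound 1 alone holding a number.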